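This account rests on a few compounds, and the source may have more. Where it says the series, first, only, none or still open, it means among the compounds named here.

Measured so far:
compound 1 `CC(=O)Nc1cc(C)n(Cc2cc(Cl)ccc2OCc2ccccc2)n1`: 316 nM in an assay on CHO-K1 cells for displacement of a labelled ligand from prostaglandin E2 receptor EP1 subtype (Homo sapiens); on this read-out lower numbers stand for stronger inhibition and higher numbers for weaker inhibition
compound 2 `Cc1cc(NC(=O)C2CCCC2)nn1Cc1cc(Cl)ccc1OCC(C)C`: 25.1 nM in this assay

Compound 1 holds the highest number of the two. Its nearest neighbour is compound 2, whose number lies lower by a margin well beyond the usual scatter. Compound 2 differs from compound 1 in more than one place, so no single step can be read between them; their two values alone show the gap.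

The next compound to examine is compound 3 `CCOC(=O)Nc1cc(C)n(Cc2cc(Cl)ccc2OCc2ccccc2)n1`. Against compound 1 the change is ethoxy in place of methyl on a carbonyl carbon, read one bond further out as acetamido to (ethoxycarbonyl)amino. For the measured compounds named here, no step between measured compounds with a single change is known, so the size of this step has no anchor. The expected step of a 1.3-fold lower number from compound 1 to compound 3 (0.10 log units; within the scatter) is small, in either direction, and not clearly beyond the scatter. Compound 3 is therefore estimated at 250 nM, with a range of 80 nM to 800 nM.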

Compound 3, half-maximal inhibitory concentration: 79.4 nM
For compound 3 the middle estimate is 3.1-fold (0.50 log units) above the measured one, outside the stated range (below it).
By their numbers in this assay, from the lowest: compound 2; then compound 3; then compound 1.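

In this assay, for the compounds shown here, ethoxy in place of methyl on a carbonyl carbon gives a 4.0-fold lower number from compound 1 to compound 3 (0.60 log units; beyond the scatter), and this is the only single-change step so far. The position therefore responds to what is attached to this carbonyl carbon, and the change from acetamido to (ethoxycarbonyl)amino is favourable here, with the rest of compound 1 left unchanged. No measurement at hand bears on the origin of this step.

Ethoxy brings in both an oxygen and a longer chain, so this single pair cannot separate the two, and a propanoyl group or a methoxycarbonyl group on the same nitrogen would pull them apart. Also open, from the compounds shown here alone, is how far the step extends along the series, for example to an amine-bearing carbamate chain or to a longer alkoxy such as butoxy.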